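The compounds below may be only part of what the source reports. "The series", "measured", "known", "first", "only" and "open" are said of these compounds alone.

Measured so far:
Compound 1, `CN(C)C(=O)c1cc2cnc(Nc3ccc(S(=O)(=O)NCCCCCN=C=S)cc3)nc2n1C1CCCC1`, gives 102%.
Compound 2, `CN(C)C(=O)c1cc2cnc(Nc3ccc(NC(=O)CCCN=C=S)cc3)nc2n1C1CCCC1`, gives 102%.

Both values come from a functional assay on A549 cells (Homo sapiens) for inhibition, read by CCK-8 assay, with a stated time of 72 h, tested at 10 uM; a higher number here means a stronger effect of the compound at the concentration tested, a lower number a weaker effect. On this read-out compound 2 stands level with compound 1: no change at the digits printed from compound 1 to compound 2 (within the scatter). That step exchanged one chain on the aromatic carbon for another, and the read-out did not move.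

Compound 3, `CN(C)C(=O)c1cc2cnc(Nc3ccc(N=C=S)cc3)nc2n1C1CCCC1`, has not yet been measured in this assay. Its change from compound 2 is a group of 3 heavy atoms (1 carbon, 1 nitrogen, 1 sulfur; no ring) in place of a group of 9 heavy atoms (5 carbon, 2 nitrogen, 1 oxygen, 1 sulfur; no ring), on an aromatic carbon. A much smaller group thus takes the place of the longer one on the same aromatic carbon. Within the data shown here, only one measured step bears on this, the one from compound 1 to compound 2, and it was flat within the scatter, which shows only that the group at this position can be altered without moving the read-out. Shortening it so far is a larger change than any measured here. Compound 3 is expected to stay close to compound 2 because compound 2 already gives 102%, near full inhibition, so the step of a number 7 percentage points lower from compound 2 to compound 3 (within the scatter) is expected to be small. The estimate for compound 3 is 95%, between 70% and 105%.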

Compound 3, a percentage reported as inhibition, at one concentration (the size of the read-out at that concentration, not a potency): 97.9%
Estimate against measurement, compound 3: 2.9 percentage points below, within the range that was stated.
By their numbers in this assay, from the lowest: compounds 3, 1 and 2 (each within the scatter of the next).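

In this assay, cutting the group on the aromatic carbon down to three heavy atoms (one carbon, one nitrogen, one sulfur) gives a number 4.1 percentage points lower from compound 2 to compound 3 (within the scatter) and a number 4.1 percentage points lower from compound 1 to compound 3 (within the scatter). The earlier pair showed only that one long chain could stand in for another, whereas this result shows that the read-out at this concentration does not need a long chain here, nor the hydrogen-bond donor that leaves with the group of compound 2. Nothing measured alongside these compounds explains this flat result.

Going by these compounds, all three compounds keep the same unit of one carbon, one nitrogen and one sulfur at the end of the group, and whether a plain amine or a carboxylic acid in its place on the aromatic carbon would hold the read-out remains open. With a single test concentration, any difference in potency among the three also remains unseen, and tests at lower concentrations would be needed to reveal one.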